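Permeability across a Urea-for-Sulfonyl Swap on the Piperidine

A few compounds are considered here, and "the series" means these few. Any claim that something is new, unique, unknown or untested is made for them only; others in the source may bear on it.

The measured compounds and their numbers in an ADME assay on Caco-2 cells (Homo sapiens) for permeability, in the apical to basolateral direction; a higher number here means that the compound crosses the layer faster, a lower number that the compound crosses the layer more slowly:
compound 1 `CC(C)NC(=O)N1CCC(CN(C2Cc3cc(C#N)ccc3N(Cc3cncn3C)C2)S(=O)(=O)c2ccccn2)CC1` gives 0.6 10^-6 cm/s
compound 2 `Cn1cncc1CN1CC(N(Cc2cccc(-n3cccc3)c2)S(=O)(=O)c2ccccn2)Cc2cc(C#N)ccc21` gives 2.3 10^-6 cm/s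
compound 3 `CCS(=O)(=O)N1CCC(CN(C2Cc3cc(C#N)ccc3N(Cc3cncn3C)C2)S(=O)(=O)c2ccccn2)CC1` gives 0.1 10^-6 cm/s

Compound 3 has the lowest of the three numbers in this assay. Its nearest neighbour is compound 1, with a 6.0-fold lower number from compound 1 to compound 3 (0.78 log units; beyond the scatter) separating them, and the widest gap is to compound 2, shown by a 23-fold lower number from compound 2 to compound 3 (1.36 log units; beyond the scatter). Compound 2 also sits above compound 1, as a 3.8-fold higher number from compound 1 to compound 2 (0.58 log units; beyond the scatter) shows.

Compound 4 `Cn1cncc1CN1CC(N(CC2CCN(C(=O)N3CCCCC3)CC2)S(=O)(=O)c2ccccn2)Cc2cc(C#N)ccc21` differs from compound 3 in one place: (piperidin-1-yl)carbonyl in place of ethylsulfonyl on an amine nitrogen in a ring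

Within the data shown here, the step that bears on this change is the one from compound 1 to compound 3, in which ethylsulfonyl replaced isopropylcarbamoyl on the same amine nitrogen in a ring and the number fell modestly, a 6.0-fold lower number from compound 1 to compound 3 (0.78 log units; beyond the scatter). Compound 4 moves in the opposite direction, putting a carbonyl-linked group back on that nitrogen, so the number is expected to rise again, roughly back toward the level of compound 1, as an 8.0-fold higher number from compound 3 to compound 4 (0.90 log units; beyond the scatter) expresses. The estimate for compound 4 in this assay is 0.8 10^-6 cm/s, with a range from 0.3 10^-6 cm/s to 2.5 10^-6 cm/s.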

Compound 4, apparent permeability: 0.6 10^-6 cm/s
Compound 4: middle estimate off by 1.3-fold (0.12 log units), on the high side; the measured number falls inside the stated range.
By their numbers in this assay, from the lowest: compound 3; then compounds 1 and 4 (each within the scatter of the next); then compound 2.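

In this assay, the move from ethylsulfonyl to (piperidin-1-yl)carbonyl on the amine nitrogen in the ring gives a 6.0-fold higher number from compound 3 to compound 4 (0.78 log units; beyond the scatter), so the higher level seen with compound 1 is not tied to a single carbonyl-linked group. The group on the carbonyl carbon also tolerates a real change at this position: piperidin-1-yl in place of isopropylamino, which adds a six-membered non-aromatic ring, gives no change at the digits printed from compound 1 to compound 4 (within the scatter). Among the compounds shown, the two carbonyl-linked groups therefore sit together and the ethylsulfonyl compound sits apart, though nothing measured here accounts for that separation.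

Because compound 3 and compound 4 differ in both the linking group and what it carries, they do not show whether the sulfonyl link itself matters, a question that a piperidin-1-ylsulfonyl group on the same nitrogen would address directly. On these data alone, it also remains open whether the carbonyl link needs a nitrogen on it at all, as a simple acetyl group or a propanoyl group would test, and whether a morpholin-4-ylcarbonyl group would stay at the level of compound 4.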